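From chloro to hydroxy on one aromatic ring

The source may hold more compounds than are shown below. What is called first, only, known or untested is meant among the compounds shown, and "the series" means these compounds.

Among the compounds with values here, in a functional assay on U-251 cells (Homo sapiens) (a lower number here means a stronger inhibitor of growth, a higher number a weaker inhibitor of growth), compound 3 `O=S(=O)(/C=C/c1ccc(Cl)cc1)Cc1ccc(Nc2ncnc3ccc(Br)cc23)cc1` gives 30000 nM as its result, the highest actual number measured so far. The nearest number belongs to compound 1 `O=S(=O)(/C=C/c1ccc(O)cc1)Cc1ccc(Nc2ncnc3ccccc23)cc1` at 300 nM and lies far lower. Compound 2 `O=S(=O)(/C=C/c1ccc(Cl)c(Cl)c1)Cc1ccc(Nc2ncnc3ccc(Br)cc23)cc1` reads > 100000 nM here, which is a limit of the assay and not a number.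

Compound 4 `O=S(=O)(/C=C/c1ccc(O)cc1)Cc1ccc(Nc2ncnc3ccc(Br)cc23)cc1` differs from compound 3 in one place: hydroxy in place of chloro on an aromatic carbon. In words, hydroxy stands in place of chloro on an aromatic carbon, turning 4-chlorophenyl into 4-hydroxyphenyl.

Within the data shown here, no measured step makes this exact swap. The closest one is an at least 3.3-fold lower number from compound 2 to compound 3 (0.52 log units; beyond the scatter) on the same ring, so changes there can move the number. Its true size is open, since one end of it is a limit. The other clue is that compound 4 shares its 4-hydroxyphenyl group with compound 1 at 300 nM on a core that is not identical, so only part of that low number is expected to carry over. The expected change is a 10-fold lower number from compound 3 to compound 4 (1.00 log units; beyond the scatter) and would lie beyond the scatter. Compound 4 is estimated at 3000 nM in this assay, with an expected range from 500 nM to 20000 nM for this uncertain step.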

Compound 4, concentration for 50% growth inhibition: > 100000 nM
Compound 4: no number, only a limit (the forecaster's own chance of this, stated with the estimate: 10%); middle value at least 33-fold (1.52 log units) away from the limit.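

Compound 4 reads > 100000 nM in this assay, which is a limit of the assay and not a number. On the bromo-bearing core, hydroxy in place of chloro at this position gives an at least 3.3-fold higher number from compound 3 to compound 4 (0.52 log units; beyond the scatter), so this swap weakens growth inhibition instead of strengthening it, and the 4-hydroxyphenyl group does not by itself bring a low number. With that group held fixed, bromo in place of hydrogen on the core gives an at least 330-fold higher number from compound 1 to compound 4 (2.52 log units; beyond the scatter), which ties the low number of compound 1 to the core without bromo and shows that a result for this ring cannot be carried from one core to the other.

On these data alone, the step from compound 2 to compound 4 cannot be read, and the true sizes of the other two new steps stay open, since each has a limit at one end: the limit of > 100000 nM in this assay, at which 2 of the 4 values shown sit. Also open, as far as these compounds go, is whether a methoxy or an amine at this position on the bromo-bearing core would give a readable number, and how chloro would read on the core of compound 1.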